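A few compounds are considered here, and "the series" means these few. Any claim that something is new, unique, unknown or untested is made for them only; others in the source may bear on it.

In a functional assay on HCT-116 cells (Homo sapiens), read by MTT assay, with a stated time of 72 h (a lower number here means a stronger inhibitor, a higher number a weaker inhibitor), compound 1 `COc1nc(N)nc2c1c(-c1ccsc1)cn2[C@@H]1O[C@H](CO)[C@@H](O)[C@H]1O` gives only a limit, > 20000 nM.
In this assay compound 2 `C#Cc1cn([C@@H]2O[C@H](CO)[C@@H](O)[C@H]2O)c2nc(N)nc(OC)c12` likewise gives only a limit, > 20000 nM.
In this assay compound 3 `C#Cc1cn([C@@H]2O[C@H](CO)[C@@H](O)[C@H]2O)c2ncnc(SC)c12` gives 30 nM.

Compound 3 is the only one of the three with a number; the other two sit at the limit of > 20000 nM in this assay, at which 2 of the 3 values shown sit. The step that the two limits leave unreadable from compound 2 to compound 1 therefore cannot be read. The difference between the core of compound 2 and the core of compound 3 is not broken down here. Compound 4 `CSc1ncnc2c1c(-c1ccsc1)cn2[C@@H]1O[C@H](CO)[C@@H](O)[C@H]1O` differs from compound 3 by thiophen-3-yl in place of ethynyl on an aromatic carbon, the same change as thiophen-3-yl in place of ethynyl on an aromatic carbon, made at a place described in the same words. Since the measured step is unreadable, the expectation rests only on compound 3 at 30 nM and on the size of the group entering. Compound 4 is expected at 150 nM, between 20 nM and 2000 nM, a step of a 5.0-fold higher number from compound 3 to compound 4 (0.70 log units; beyond the scatter).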

Compound 4, half-maximal inhibitory concentration: > 20000 nM
Compound 4 gave a limit, no number; the forecaster's own chance of this, stated with the estimate: 12%; middle value at least 130-fold (2.12 log units) away from the limit.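

On the core of compound 3, thiophen-3-yl in place of ethynyl on an aromatic carbon gives an at least 660-fold higher number from compound 3 to compound 4 (2.82 log units; beyond the scatter) in this assay. As far as these compounds go, compound 4 gives > 20000 nM, which is a limit and not a number, so this step shows a large loss whose full size stays unknown. The same change on the core of compound 2 cannot be read, so whether it acts alike on both cores is not shown, as most compounds here stop at one limit: the limit of > 20000 nM in this assay, at which 3 of the 4 values shown sit.

Open, from the compounds shown here alone, is how a nitrile or a methyl would fare at this place on the core of compound 3. Going by these compounds, an amine there is equally open, as is whether any group at this place on the core of compound 2 would give a number.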